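Three Measured Compounds and a Fourth Awaiting Its Number

The source may hold more compounds than are shown below. What is called first, only, known or untested is meant among the compounds shown, and "the series" means these compounds.

Measured so far:
- compound 1, `CCCC/C=C\CCCCCCCCCc1cc(=O)c2c(O)c(C)c(OCOC)cc2o1`: > 67200 nM, a limit
- compound 2, `CCCCC/C=C\C/C=C\CCCCCCCc1cc(=O)c2c(O)c(C)c(OCOC)cc2o1`: > 67200 nM, a limit
- compound 3, `CCCC/C=C\CCCCCCCCCc1cc(=O)c2c(O)cc(O)cc2o1`: 17500 nM

All three were tested in a functional assay on MCF7 cells (Homo sapiens) for antiproliferative activity, read by MTT assay; on this read-out lower numbers stand for stronger inhibition and higher numbers for weaker inhibition. The value of compound 1, > 67200 nM, is a limit of the assay and not a number. The value of compound 2, > 67200 nM, is likewise a limit. Compound 3 is the only one of the three that gives a number, 17500 nM.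

Compound 1 and compound 2 share one core and differ in a single place: deca-1,4-dien-1-yl in place of oct-3-en-1-yl on a saturated chain carbon, seven bonds along the chain from an aromatic carbon. The step between them in this assay is a step that the two limits leave unreadable from compound 1 to compound 2, and it stays unreadable due to the limit of > 67200 nM in this assay, at which 2 of the 3 values shown sit. How the core of compound 3 differs from the core of compound 1 is not broken down here.

Compound 4, `CCCCC/C=C\C/C=C\CCCCCCCc1cc(=O)c2c(O)cc(O)cc2o1`, has not yet been measured. It stands to compound 3 exactly as compound 2 stands to compound 1: deca-1,4-dien-1-yl in place of oct-3-en-1-yl on a saturated chain carbon, seven bonds along the chain from an aromatic carbon, the same change at the same place.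

The step expected in this assay is a 1.1-fold higher number from compound 3 to compound 4 (0.06 log units; within the scatter), kept small because a step that the two limits leave unreadable from compound 1 to compound 2 could not be read and so offers no ground for a large change. Compound 4 is therefore expected to give about 20000 nM. The likely range for compound 4 runs from 7000 nM to 60000 nM.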

Compound 4, half-maximal inhibitory concentration: 17500 nM
Estimate against measurement, compound 4: 1.1-fold (0.06 log units) above, within the range that was stated.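

In this assay putting deca-1,4-dien-1-yl in place of oct-3-en-1-yl, on a saturated chain carbon, seven bonds along the chain from an aromatic carbon, gives no change at the digits printed from compound 3 to compound 4 (within the scatter) and so the two chains cannot be told apart on the core of compound 3 in this read-out. This rests on a single pair of compounds, so it shows that the change is tolerated on this one core and gives no general rule for other cores in the series. The same change on the core of compound 1 offers no second reading, since compound 1 and compound 2 each carry a limit of the assay and not a number, and their step cannot be read because of what the assay could report: the limit of > 67200 nM in this assay, at which 2 of the 4 values shown sit.

On these data alone, it therefore stays open whether the change would also leave the number in place on a core where both partners give a real value. Also open is how the core of compound 3 would respond to a much shorter chain, a longer chain, or a chain ending in a carboxylic acid or an amine, none of which is among the compounds shown.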